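Adding an acylurea to the distal ring of compound 1

The compounds below may be only part of what the source reports. "The series", "measured", "known", "first", "only" and "open" are said of these compounds alone.

Compound 1, `C/C(=N\OC(=O)Nc1ccccc1)c1cccc(-c2ccccc2)c1`, sits second highest of the three numbers measured in an assay for inhibition of Fatty-acid amide hydrolase 1 (Mus musculus), read by scintillation counting (on this read-out lower numbers stand for stronger inhibition and higher numbers for weaker inhibition), where compound 1 gives 69 nM. Compound 2, `C/C(=N\OC(=O)Nc1ccc(F)cc1)c1cccc(-c2ccccc2)c1`, gives 17 nM, and compound 3, `C/C(=N\OC(=O)Nc1ccc2sccc2c1)c1cccc(-c2ccccc2)c1`, gives 232 nM. The step of a 4.1-fold lower number from compound 1 to compound 2 (0.61 log units; beyond the scatter) and the step of a 3.4-fold higher number from compound 1 to compound 3 (0.53 log units; beyond the scatter) both lie at the carbamate nitrogen. The step of a 14-fold higher number from compound 2 to compound 3 (1.14 log units; beyond the scatter) covers the same site.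

Compound 4, `C/C(=N\OC(=O)Nc1ccccc1)c1cccc(-c2cccc(C(=O)NC(=O)Nc3ccccc3)c2)c1`, differs from compound 1 elsewhere: (phenylcarbamoyl)carbamoyl in place of hydrogen on an aromatic carbon, on an aromatic carbon of a six-membered aromatic ring of carbon only, meta to a large group. For the measured compounds named here, none of the measured steps touches this part of the shared core, so they do not bear directly on the change, and the data give no basis for expecting a step beyond the scatter in either direction in this assay.

The account therefore expects compound 4 to give about 100 nM, with a likely range from 30 nM to 350 nM, the expected step being a 1.4-fold higher number from compound 1 to compound 4 (0.16 log units; within the scatter).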

Compound 4, half-maximal inhibitory concentration: > 25000 nM
Compound 4 gave a limit, no number (the forecaster's own chance of this, stated with the estimate: 5%); middle value at least 250-fold (2.39 log units) from the limit.
By their numbers in this assay, from the lowest: compound 2; then compound 1; then compound 3. At a limit, above all of these: compound 4.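

Compound 4 stands at a limit in this assay, not at a number: the limit of > 25000 nM in this assay, at which 1 of the 4 values shown sits.

Setting (phenylcarbamoyl)carbamoyl in place of hydrogen gives an at least 360-fold higher number from compound 1 to compound 4 (2.55 log units; beyond the scatter). For the compounds shown here, the earlier compounds varied only the carbamate nitrogen, where the widest step is a 14-fold higher number from compound 2 to compound 3 (1.14 log units; beyond the scatter), so this is the first sign that the aromatic carbon meta to a large group is also a sensitive place on the shared core, and that a change there can cost more than any change at that nitrogen.

From the compounds shown here alone, whether a smaller group at this place, such as a methyl, a primary carboxamide or a carboxylic acid, would keep the number close to that of compound 1 remains open. Also open, going by these compounds, is how much of the loss belongs to the phenyl of the new group and how much to the acylurea itself.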